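Chloro to bromo on the fused guanidine series

The source may report more compounds than this note shows. Statements on the series, on what has been measured and on what is new or still open speak of the compounds shown alone.

Compound 3 `Cc1nc(N=C(N)N)nc2cc(Cl)ccc12` gives 96 nM in an assay on isolated protein for inhibition of Myeloperoxidase (Homo sapiens), with a stated time of 5 min (on this read-out higher numbers stand for weaker inhibition and lower numbers for stronger inhibition), the second highest of the three numbers measured. Compound 1 `Cc1nc(N=C(N)N)nc2ccc(F)cc12` gives 145 nM, within the scatter of compound 3, while compound 2 `Cc1nc(N=C(N)N)nc2cc(F)ccc12` gives 40 nM, and the step of a 2.4-fold higher number from compound 2 to compound 3 (0.38 log units; beyond the scatter) is modest but beyond the scatter. Compound 4 `Cc1nc(N=C(N)N)nc2cc(Br)ccc12` carries bromo in place of chloro on an aromatic carbon. Among the compounds with values here, only the step from compound 2 to compound 3 bears on this exchange, and it went toward weaker inhibition by a modest amount. A second halogen exchange on the same carbon is expected to give a small step in this assay in the same direction, or none beyond the scatter. Compound 4 is estimated at 130 nM, with a range of 55 nM to 320 nM. The expected step is a 1.4-fold higher number from compound 3 to compound 4 (0.13 log units; within the scatter).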

Compound 4, half-maximal inhibitory concentration: 106 nM
Compound 4: the middle estimate sits 1.2-fold (0.09 log units) above what was measured; measured number inside the range.
By their numbers in this assay, from the lowest: compound 2; then compounds 3, 4 and 1 (each within the scatter of the next).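

In this assay, chloro and bromo on this aromatic carbon cannot be told apart (a 1.1-fold higher number from compound 3 to compound 4 (0.04 log units; within the scatter)), so the halogen exchange has no further effect beyond chloro. Only fluoro stands apart among the three halogens here (a 2.7-fold higher number from compound 2 to compound 4 (0.42 log units; beyond the scatter)), which makes compound 2 the single beyond-scatter point at this carbon. Nothing measured explains why fluoro differs from chloro and bromo. Still open, as far as these compounds go, is whether a non-halogen group on the same carbon, such as an amine or a carboxylic acid, would stay near compound 2 or move away from it.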